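The source may report more compounds than this note shows. Statements on the series, on what has been measured and on what is new or still open speak of the compounds shown alone.

Working notes on the series. In a functional assay on T47D cells (Homo sapiens) for cytotoxicity, read by CCK-8 assay and cell counting, with a stated time of 2 days (a higher number here means a weaker inhibitor, a lower number a stronger inhibitor), compound 1 `Oc1ccc(-c2cc(-c3ccc(Cl)cc3)nc(-c3cccs3)c2)cc1` gives 6450 nM. Compound 2 `Oc1ccc(-c2cc(-c3cccc(Cl)c3)nc(-c3cccs3)c2)cc1` gives 5350 nM in this assay; the change between them is 3-chlorophenyl in place of 4-chlorophenyl on an aromatic carbon, and the step is a 1.2-fold lower number from compound 1 to compound 2 (0.08 log units; within the scatter). Compound 3 `Oc1cccc(-c2cc(-c3ccc(Cl)cc3)nc(-c3ccsc3)c2)c1` gives 11500 nM in this assay; how its core differs from the core of compound 1 is not broken down here.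

Compound 4 `Oc1cccc(-c2cc(-c3ccsc3)nc(-c3cccc(Cl)c3)c2)c1` is not yet measured. It differs from compound 3 by 3-chlorophenyl in place of 4-chlorophenyl on an aromatic carbon, the same kind of change as from compound 1 to compound 2, though the surroundings differ: there the place is meta to a 4-hydroxyphenyl group and a thiophen-2-yl group, here meta to a 3-hydroxyphenyl group and a thiophen-3-yl group. Because the step of a 1.2-fold lower number from compound 1 to compound 2 (0.08 log units; within the scatter) lay within the scatter, for compound 4 a similar small step is expected, a 1.2-fold lower number from compound 3 to compound 4 (0.08 log units; within the scatter). Compound 4 is thus estimated at 9500 nM in this assay, with a range from 4500 nM to 20000 nM.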

Compound 4, half-maximal inhibitory concentration: 3540 nM
Compound 4: middle estimate off by 2.7-fold (0.43 log units), on the high side, outside the stated range (below it).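

In this assay, 3-chlorophenyl in place of 4-chlorophenyl gives a 3.2-fold lower number from compound 3 to compound 4 (0.51 log units; beyond the scatter), so on this core the change counts for more than on the core of compound 1. The change does not carry over between the two cores at a fixed size: the same change on two cores in this assay, a 1.2-fold lower number (0.08 log units; within the scatter) from compound 1 to compound 2 and a 3.2-fold lower number (0.51 log units; beyond the scatter) from compound 3 to compound 4, 2.7-fold (0.43 log units) apart, beyond the scatter of two such steps Two pairs cannot show which difference between the cores sets the size of the step, the 3-hydroxyphenyl group in place of the 4-hydroxyphenyl group or the thiophen-3-yl group in place of the thiophen-2-yl group, or the two together.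

The compounds shown leave open how each of these two groups acts alone. They also leave open what an amine or a carboxylic acid in place of the chlorine would do on either core.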